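Trimethoxyphenyl at the alkene end of a chalcone-like core

The compounds below may be only part of what the source reports. "The series", "measured", "known", "first", "only" and "open" are said of these compounds alone.

Measured compounds:
Compound 1 `COc1ccc(/C=C/C(=O)c2cc(-c3ccc(OC)c(OC)c3)n3nc(-c4ccccc4)cc3n2)cc1`: 19300 nM
Compound 2 `COc1ccc(-c2cc(/C=C/C(=O)c3ccc(C)cc3)nc3cc(-c4ccccc4)nn23)cc1OC`: 17200 nM
Compound 3 `COc1ccc(/C=C/C(=O)c2cc(-c3cc(OC)c(OC)c(OC)c3)n3nc(-c4ccccc4)cc3n2)cc1`: 21200 nM

In a functional assay on A549 cells (Homo sapiens) for antiproliferative activity, read by MTT assay, with a stated time of 24 h (on this read-out higher numbers stand for weaker inhibition and lower numbers for stronger inhibition), compound 1 gives 19300 nM, the second highest of the three numbers. Its neighbours sit close on either side: compound 3 is at 21200 nM and compound 2 at 17200 nM, and both steps, a 1.1-fold higher number from compound 1 to compound 3 (0.04 log units; within the scatter) and a 1.1-fold lower number from compound 1 to compound 2 (0.05 log units; within the scatter), stay within the scatter, so the three measured compounds cannot be told apart on this read-out.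

Compound 4 `COc1ccc(-c2cc(C(=O)/C=C/c3cc(OC)c(OC)c(OC)c3)nc3cc(-c4ccccc4)nn23)cc1OC` has not been measured. It differs from compound 1 in one place: 3,4,5-trimethoxyphenyl in place of 4-methoxyphenyl on a double-bonded chain carbon bound to a double-bonded chain carbon. Among the compounds with values here, the closest precedent is the step from compound 1 to compound 3, where a methoxy was added to the aromatic ring on the other side of the shared core, giving a 1.1-fold higher number from compound 1 to compound 3 (0.04 log units; within the scatter), a change within the scatter. Within the data shown here, the change to compound 4 adds methoxy groups in the same manner, but on the ring carried by the double-bonded chain, where no measured step exists. On the evidence available, no shift beyond the scatter is expected in this assay, so a 1.0-fold lower number from compound 1 to compound 4 (0.01 log units; within the scatter) is the estimated step. Compound 4 is therefore expected to give about 19000 nM, with a range from 9000 nM to 40000 nM.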

Compound 4, half-maximal inhibitory concentration: 15400 nM
Estimate against measurement, compound 4: 1.2-fold (0.09 log units) above, within the range that was stated.
By their numbers in this assay, from the lowest: compounds 4, 2, 1 and 3 (each within the scatter of the next).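

In this assay, placing 3,4,5-trimethoxyphenyl in place of 4-methoxyphenyl on a double-bonded chain carbon bound to a double-bonded chain carbon gives a 1.3-fold lower number from compound 1 to compound 4 (0.10 log units; within the scatter). Within the data shown here, this is the first reading at this position, and it shows that the larger group, with 12 heavy atoms against 8 and 3 hydrogen-bond acceptors against 1, leaves the number within the scatter, as did the added methoxy on the other ring, which gave a 1.1-fold higher number from compound 1 to compound 3 (0.04 log units; within the scatter). Nothing available explains why the number stays within the scatter at this position.

Going by these compounds, all the groups compared at these two rings are methoxy-bearing phenyl groups, so it remains open whether an amine or a carboxylic acid on the ring at this position would move the number beyond the scatter. On these data alone, it is equally open whether a longer chain between the carbonyl and this ring, or a plain phenyl in place of 4-methoxyphenyl, would separate any compound from compound 1.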